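The source may hold more compounds than are shown below. What is called first, only, known or untested is meant among the compounds shown, and "the series" means these compounds.

In a functional assay on NUGC-3 cells (Homo sapiens) for cytotoxicity, read by sulforhodamine B assay, with a stated time of 72 h (on this read-out higher numbers stand for weaker inhibition of growth and lower numbers for stronger inhibition of growth), compound 1 `O=C(Nc1ccc(C(F)(F)F)cc1)C1CCc2ccccc2N1` gives 18600 nM and compound 2 `COc1ccc(NC(=O)C2CCc3ccccc3N2)cc1` gives 51900 nM, so compound 2 holds the higher of the two numbers and is the weaker growth inhibitor of the pair. Compound 3 `O=C(Nc1ccccc1)C1CCc2ccccc2N1` has not yet been measured. Among the measured compounds shown here, it keeps the shared core and the amide, and only one substituent changes: hydrogen in place of methoxy on an aromatic carbon. In words, this is hydrogen in place of methoxy on an aromatic carbon.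

For the measured compounds named here, one measured step bears on this change, and it alters a group at the same place on the ring. It is the modest step of a 2.8-fold higher number from compound 1 to compound 2 (0.45 log units; beyond the scatter), which came from methoxy in place of trifluoromethyl. A single step gives no rule for a ring without a substituent, so the expectation is loose. With compound 1 at 18600 nM and compound 2 at 51900 nM, a step smaller than the measured one, towards a lower number, seems most likely, and it may not clear the scatter. The estimated step is a 1.6-fold lower number from compound 2 to compound 3 (0.20 log units; within the scatter). Compound 3 is expected at 33000 nM, with an estimated range of 14000 nM to 75000 nM.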

Compound 3, concentration for 50% growth inhibition: 59000 nM
Estimate against measurement, compound 3: 1.8-fold (0.25 log units) below; low and high end bracket the measured number.
By their numbers in this assay, from the lowest: compound 1; then compounds 2 and 3 (each within the scatter of the next).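

In this assay, placing hydrogen instead of methoxy on this aromatic carbon, para to a large group, gives a 1.1-fold higher number from compound 2 to compound 3 (0.06 log units; within the scatter), so on this read-out the methoxy compound and the compound with no substituent on that ring cannot be told apart. Hydrogen in place of trifluoromethyl gives a 3.2-fold higher number from compound 1 to compound 3 (0.50 log units; beyond the scatter), which makes compound 1 the strongest growth inhibitor of the three. Trifluoromethyl stands apart from the other two groups, while methoxy reads the same as plain hydrogen. Nothing measured on these compounds explains why trifluoromethyl alone differs from the other two groups.

Among the compounds shown here, with only three groups at this one place, it remains open whether the lower number belongs to trifluoromethyl alone or would also appear with a group such as chlorine, a nitrile or a carboxylic acid. It is also unknown whether trifluoromethyl would keep its edge at another carbon of the same ring, or with changes to the amide or the shared core.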